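Hydrazide in place of methyl amide on the shared core

The source may hold more compounds than are shown below. What is called first, only, known or untested is meant among the compounds shown, and "the series" means these compounds.

Among the measured compounds shown here, compound 3, `CNC(=O)c1ccc(NCc2nc(-c3ccccc3)nn2-c2ccccc2)cc1`, gives -3.6% in an assay on Sf9 cells for inhibition of protein deacetylase HDAC6 (Homo sapiens), read by fluorescence, with a stated time of 40 min, tested at 100 nM (on this read-out higher numbers stand for more inhibition at the one concentration tested (going by the name of the read-out) and lower numbers for less inhibition), and stands lowest of the three numbers measured so far. Its nearest neighbour is compound 1, `O=C(O)c1ccc(NCc2nc(-c3ccccc3)nn2-c2ccccc2)cc1`, which gives -0.4%; the two are within the scatter of each other. Far above both is compound 2, `O=C(NO)c1ccc(NCc2nc(-c3ccco3)nn2-c2ccccc2)cc1`, at 59.9%, which differs from compound 3 in more than one place and therefore gives no single step to read.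

For the measured compounds named here, the one measured step that touches the carbonyl position is the change from compound 1 to compound 3, a number 3.2 percentage points lower from compound 1 to compound 3 (within the scatter); a swap at this position left the number essentially where it was.

Compound 4, `NNC(=O)c1ccc(NCc2nc(-c3ccccc3)nn2-c2ccccc2)cc1`, is the next compound, differing from compound 3 only as follows: amino in place of methyl on an amide-type nitrogen. Going by the values given here, no measured step bears directly on this exchange, so the expectation rests on the fact that the only change seen so far at the carbonyl position, the step from compound 1 to compound 3, stayed within the scatter, while the much higher number of compound 2 came with a different group on the carbonyl carbon. The step from compound 3 to compound 4 is therefore expected to be small, a number 11.6 percentage points higher from compound 3 to compound 4 (beyond the scatter), with a wide range to the upside. Compound 4 is estimated at 8%, between -8% and 40%.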

Compound 4, a percentage reported as inhibition, at one concentration (the size of the read-out at that concentration, not a potency): 10%
The estimate for compound 4 lay 2 percentage points below the measured number, and the stated range covers the measured number.
By their numbers in this assay, from the lowest: compounds 3 and 1 (each within the scatter of the next); then compound 4; then compound 2.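

In this assay, the group on the carbonyl carbon now gives a step beyond the scatter, though a modest one: amino in place of methyl on an amide-type nitrogen (a number 13.6 percentage points higher from compound 3 to compound 4 (beyond the scatter)), whereas the earlier swap at this carbon stayed within the scatter (a number 3.2 percentage points lower from compound 1 to compound 3 (within the scatter)). The hydroxy comparison points the same way, with aminoamino in place of hydroxy on the carbonyl carbon (a number 10.4 percentage points higher from compound 1 to compound 4 (beyond the scatter)), so aminoamino separates from both methylamino and hydroxy on the shared core, and the exchange of a single heavy atom is enough to do so. Nothing measured here accounts for this step, and the added hydrogen-bond donor and acceptor remain only a count from the two structures.

As far as these compounds go, compound 2 differs from the other compounds in more than one place, so what a hydroxyamino group on the carbonyl carbon would give by itself on the shared core remains open. Also open, from the compounds shown here alone, is whether the step is tied to the amino group specifically, which a methoxyamino group, a dimethylamino group or a longer chain such as ethylamino at this place could help to settle.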